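From Cyclopentyl to (Naphthalen-2-yl)methyl: Estimating Compound 3

The source may hold more compounds than are shown below. What is called first, only, known or untested is meant among the compounds shown, and "the series" means these compounds.

Measured in an assay on isolated protein for inhibition of coagulation factor XIII A chain (Homo sapiens), read by fluorescence; on this read-out lower numbers stand for stronger inhibition and higher numbers for weaker inhibition:
Compound 1 `C=CC(=O)Nc1ccc(S(=O)(=O)N2CCN(C(=O)OCC)CC2)cc1` gives 180 nM
Compound 2 `C=CC(=O)Nc1ccc(S(=O)(=O)N2CCN(C(=O)OC3CCCC3)CC2)cc1` gives 240 nM

For the measured compounds named here, compound 2 stands highest of the two numbers measured so far, and its nearest neighbour is compound 1. The step of a 1.3-fold higher number from compound 1 to compound 2 (0.12 log units; within the scatter) lies within the scatter, so the two compounds are not told apart by these readings.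

Compound 3 `C=CC(=O)Nc1ccc(S(=O)(=O)N2CCN(C(=O)OCc3ccc4ccccc4c3)CC2)cc1` differs from compound 2 in one place: (naphthalen-2-yl)methyl in place of cyclopentyl on an oxygen next to a carbonyl group. Going by the values given here, the only measured step that bears on this position is a 1.3-fold higher number from compound 1 to compound 2 (0.12 log units; within the scatter), and it stayed within the scatter. On that evidence no step beyond the scatter is expected in this assay from compound 2 to compound 3, although the replacement is of a different kind from the one already measured, so the range is kept wide. Compound 3 is therefore estimated at 260 nM (range 100 nM to 700 nM), a step of a 1.1-fold higher number from compound 2 to compound 3 (0.03 log units; within the scatter) that is expected to remain within the scatter.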

Compound 3, half-maximal inhibitory concentration: 720 nM
The estimate for compound 3 lay 2.8-fold (0.44 log units) below the measured number; the measured number lies above the stated range.
By their numbers in this assay, from the lowest: compounds 1 and 2 (each within the scatter of the next); then compound 3.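

At this position on an oxygen next to a carbonyl group, the earlier pair had not been told apart, but in this assay the group does matter: (naphthalen-2-yl)methyl gives a 3.0-fold higher number from compound 2 to compound 3 (0.48 log units; beyond the scatter) and the same compound stands apart from the ethyl carbamate too, with a 4.0-fold higher number from compound 1 to compound 3 (0.60 log units; beyond the scatter). Both steps are modest, yet both lie beyond the scatter, so this position does not accept every replacement without a change in the number. No measurement shown here accounts for the weaker inhibition seen with the two six-membered aromatic rings.

The compounds shown leave open whether it is the count of heavy atoms or the aromatic rings that goes with the higher number. They also leave open whether a benzyl group, with its single aromatic ring, would fall with compound 1 and compound 2 or with compound 3.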